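Swapping a methyl for a methoxy on the sulfonyl aryl

The compounds below may be only part of what the source reports. "The series", "measured", "known", "first", "only" and "open" are said of these compounds alone.

Of the compounds shown here, three sharing one core have been measured in a functional assay on HeLa cells for antagonist activity at 5-hydroxytryptamine receptor 6 (Homo sapiens); on this read-out lower numbers stand for stronger inhibition and higher numbers for weaker inhibition. Compound 1 `Cc1ccc(S(=O)(=O)c2n[nH]c3ccc(N4CCN(C)CC4)cc23)cc1` gives 112 nM and stands highest of the three. Compound 2 `CN1CCN(c2ccc3c(c2)c(S(=O)(=O)c2cccc4ccccc24)nn3Cc2ccccc2)CC1` gives 2 nM, and compound 3 `CC(C)Cn1nc(S(=O)(=O)c2cccc3ccccc23)c2cc(N3CCN(C)CC3)ccc21` gives 1.4 nM; both carry a larger aryl group on the sulfonyl sulfur and a substituent on a ring nitrogen, so they differ from compound 1 in more than one place, and the gap between compound 1 and either of them is wide. Going by the values given here, the only single change measured, a 1.4-fold lower number from compound 2 to compound 3 (0.15 log units; within the scatter), swaps isopropyl for phenyl on a saturated chain carbon bound to an aromatic nitrogen and lies within the scatter.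

Compound 4 `COc1cccc(S(=O)(=O)c2n[nH]c3ccc(N4CCN(C)CC4)cc23)c1` differs from compound 1 by 3-methoxyphenyl in place of 4-methylphenyl on a sulfonyl sulfur. Among the compounds with values here, no measured step touches the group on the sulfonyl sulfur, so there is no direct guide. Compound 4 is therefore expected to show no step beyond the scatter, a 1.1-fold lower number from compound 1 to compound 4 (0.05 log units; within the scatter), with an estimated value of 100 nM in this assay, between 35 nM and 300 nM.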

Compound 4, half-maximal inhibitory concentration: 57 nM
The estimate for compound 4 lay 1.8-fold (0.24 log units) above the measured number; the range from low to high includes it.
By their numbers in this assay, from the lowest: compounds 3 and 2 (each within the scatter of the next); then compounds 4 and 1 (each within the scatter of the next).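

Going by these compounds alone, this is the first measured step at the group on the sulfonyl sulfur. In this assay, a 2.0-fold lower number from compound 1 to compound 4 (0.29 log units; within the scatter) stays within the scatter, so this swap, which adds one oxygen and one hydrogen-bond acceptor, does not separate the two compounds on the core of compound 1. No measurement bears on why the change leaves the two compounds inseparable here.

The step changes both the substituent and its printed ring position, so the compounds shown leave open whether 4-methoxyphenyl or 3-methylphenyl would also stay within the scatter. They also leave open whether a phenyl ring carrying an amine or a carboxylic acid on the same core would give a step beyond the scatter.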